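Swapping a carbamate chain for a hydroxymethyl piperidine

The source may report more compounds than this note shows. Statements on the series, on what has been measured and on what is new or still open speak of the compounds shown alone.

Measured compounds:
Compound 1 `CC(C)(C)OC(=O)NCCNC(=O)CN1CN(c2ccccc2)C2(CCN(C(=O)c3ccc(C(C)(C)C)cc3)CC2)C1=O`: 10900 nM
Compound 2 `O=C(CN1CN(c2ccccc2)C2(CCN(C(=O)c3ccc(C4CCCCC4)cc3)CC2)C1=O)N1CCC(CO)CC1`: 1100 nM
Compound 3 `CC1CCCN(C(=O)CN2CN(c3ccccc3)C3(CCN(C(=O)c4ccc(C5CCCCC5)cc4)CC3)C2=O)C1`: 3600 nM

All three compounds were tested in an assay on HEK293 cells for displacement of a labelled ligand from NPC1-like intracellular cholesterol transporter 1 (Homo sapiens); on this read-out lower numbers stand for stronger inhibition and higher numbers for weaker inhibition. Compound 1 gives the highest number of the three; compound 3 sits nearest to it, and compound 2 furthest, so compound 1 is the weakest of the measured set on this read-out.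

The new compound, compound 4 `CC(C)(C)c1ccc(C(=O)N2CCC3(CC2)C(=O)N(CC(=O)N2CCCC(CO)C2)CN3c2ccccc2)cc1`, keeps the core of compound 1 but changes the amide: 3-(hydroxymethyl)piperidin-1-yl in place of (2-((tert-butoxycarbonyl)amino)ethyl)amino on a carbonyl carbon. For the measured compounds named here, the one measured step that speaks to an amide change of this kind is a 3.3-fold higher number from compound 2 to compound 3 (0.51 log units; beyond the scatter), in which a piperidine carrying a hydroxymethyl gave the lower number. Going by the values given here, no measured pair directly compares an open carbamate chain with a cyclic amide, and compound 4 keeps the tert-butyl-substituted aryl of compound 1 rather than the cyclohexyl aryl of compounds 2 and 3, so the transfer is uncertain. On balance a lower number than compound 1 is expected, with the step from compound 1 to compound 4 estimated at a 3.1-fold lower number from compound 1 to compound 4 (0.49 log units; beyond the scatter). Compound 4 is therefore expected to give about 3500 nM, within a range of 1200 nM to 10000 nM.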

Compound 4, half-maximal inhibitory concentration: 8200 nM
The estimate for compound 4 lay 2.3-fold (0.37 log units) below the measured number; measured number inside the range.
By their numbers in this assay, from the lowest: compound 2; then compound 3; then compounds 4 and 1 (each within the scatter of the next).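

In this assay, putting 3-(hydroxymethyl)piperidin-1-yl on this carbonyl carbon in place of the open carbamate chain gives a 1.3-fold lower number from compound 1 to compound 4 (0.12 log units; within the scatter), so the two compounds cannot be told apart. With the tert-butyl aryl kept, a chain with no ring and a group with a six-membered ring therefore read alike at this position, and a hydroxymethyl piperidine on its own does not separate itself from the carbamate chain. No measurement shown here offers an explanation for this result.

Compound 4 and compound 2 differ in two places, so the separate contributions of the aryl substituent and of the hydroxymethyl position remain unresolved. On these data alone, it also remains open how this position would respond to a piperidine carrying a primary amine or a carboxylic acid in place of the hydroxymethyl.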